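Alkyne-linked aryl replacement on the shared core

The compounds below may be only part of what the source reports. "The series", "measured", "known", "first", "only" and "open" are said of these compounds alone.

Measured so far:
- compound 1, `COc1cccc(C#Cc2sc3c(c2C(=O)N[C@@H](C)c2ccc(C(=O)O)cc2)CCOC3)c1`: 12.4 nM
- compound 2, `C[C@H](NC(=O)c1c(CCc2ccc(F)cc2)sc2c1CC(C)(C)OC2)c1ccc(C(=O)O)cc1`: 36.2 nM

In a functional assay on CHO/Galpha16 cells for antagonist activity at prostaglandin E2 receptor EP4 subtype (Homo sapiens), read by calcium flux, with a stated time of 15 min (a lower number here means a stronger inhibitor, a higher number a weaker inhibitor), compound 1 gives 12.4 nM. This is the lowest of the two numbers at hand; compound 2 gives the higher number, and the gap between the two lies beyond the scatter. Within the data shown here, no single-point step links compound 1 and compound 2, since the two differ in more than one place, so their values show only that compound 1 is the stronger inhibitor of the pair in this assay.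

The step followed here leads from compound 1 to compound 3, `C[C@H](NC(=O)c1c(C#Cc2ccc(=O)[nH]c2)sc2c1CCOC2)c1ccc(C(=O)O)cc1`, which has not yet been measured in this assay. The change is a group of 7 heavy atoms (5 carbon, 1 nitrogen, 1 oxygen; one six-membered aromatic ring with 1 hetero atom) in place of a group of 8 heavy atoms (7 carbon, 1 oxygen; one six-membered aromatic ring of carbon only), on a triple-bonded carbon

Among the measured compounds shown here, no comparable step is available among the measured compounds. As far as these compounds go, the group that leaves, 3-methoxyphenyl, is exchanged on the triple-bonded carbon for a group of similar size carrying one hydrogen-bond donor and one acceptor; the effect of such an exchange is unknown, so a modest shift toward a higher number, or none beyond the scatter, is expected. For compound 3 the expected value in this assay is 25 nM, with a range from 8 nM to 80 nM, which corresponds to an estimated step of a 2.0-fold higher number from compound 1 to compound 3 (0.30 log units; within the scatter).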

Compound 3, half-maximal inhibitory concentration: 642 nM
Compound 3: the middle estimate sits 26-fold (1.41 log units) below what was measured; the whole stated range lies below it.
By their numbers in this assay, from the lowest: compound 1; then compound 2; then compound 3.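

In this assay, exchanging 3-methoxyphenyl on the triple-bonded carbon for the group with a six-membered aromatic ring with 1 hetero atom gives a 52-fold higher number from compound 1 to compound 3 (1.71 log units; beyond the scatter), so this position is far from indifferent to the group it carries. The step is large although the heavy-atom count moves only from 8 to 7 and the hydrogen-bond acceptor count stays the same; the entering group adds 1 hydrogen-bond donor and 1 double bond outside aromatic rings. The earlier pair differed in more than one place and could not isolate this position, and no measurement at hand bears on the origin of the step.

Still open, as far as these compounds go, is which feature of the entering group carries the step, since the ring hetero atom, the carbonyl and the hydrogen-bond donor all change together in this single exchange. Unsubstituted phenyl, a pyridyl ring without the carbonyl, and the same ring with a methyl group on its nitrogen would each separate these features on the triple-bonded carbon.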